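The source may report more compounds than this note shows. Statements on the series, on what has been measured and on what is new or still open speak of the compounds shown alone.

Measured so far:
- compound 1 `O=C(O)[C@H]1CC[C@H](C(=O)N2CC[C@](c3ccc(C(OCc4ccccc4OC(F)(F)F)(C(F)(F)F)C(F)(F)F)cc3)(S(=O)(=O)c3ccc(F)cc3)C2)CC1`: 93%
- compound 2 `Cc1cccc(F)c1COC(c1ccc([C@]2(S(=O)(=O)c3ccc(F)cc3)CCN(C(=O)[C@H]3CC[C@H](C(=O)O)CC3)C2)cc1)(C(F)(F)F)C(F)(F)F`: 79%
- compound 3 `O=C(O)[C@H]1CC[C@H](C(=O)N2CC[C@](c3ccc(C(OCc4c(F)cccc4Cl)(C(F)(F)F)C(F)(F)F)cc3)(S(=O)(=O)c3ccc(F)cc3)C2)CC1`: 100%

In an ADME assay on microsomes from liver (Homo sapiens) for metabolic stability, with a stated time of 10 min (on this read-out lower numbers stand for a less stable compound and higher numbers for a more stable compound), compound 3 is level with compound 1 within the scatter, as the reading a number 7 percentage points higher from compound 1 to compound 3 (within the scatter) shows. It stands clear of compound 2, with a number 21 percentage points higher from compound 2 to compound 3 (beyond the scatter).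

Compound 4 `COc1cccc(F)c1COC(c1ccc([C@]2(S(=O)(=O)c3ccc(F)cc3)CCN(C(=O)[C@H]3CC[C@H](C(=O)O)CC3)C2)cc1)(C(F)(F)F)C(F)(F)F` carries methoxy in place of chloro on an aromatic carbon. Within the data shown here, no measured step has methoxy entering, so the evidence is indirect. The nearest step is chloro in place of methyl on an aromatic carbon, a number 21 percentage points higher from compound 2 to compound 3 (beyond the scatter). It suggests that losing chloro for methoxy could cost a modest amount. Against this, compound 1, with its 2-(trifluoromethoxy)phenyl group, gives 93%, and the step to its methyl-bearing partner is a number 14 percentage points lower from compound 1 to compound 2 (beyond the scatter). A fall in this assay is therefore expected, probably smaller than the step from the chloro and methyl pair, and it may not clear the scatter by much.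

The expected change is a number 16 percentage points lower from compound 3 to compound 4 (beyond the scatter).

For compound 4 the estimated value is 84%, with an expected range of 66% to 98%.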

Compound 4, percent of the compound remaining: 82%
Beside the measured number, compound 4's estimate is 2 percentage points above it; low and high end bracket the measured number.
By their numbers in this assay, from the lowest: compounds 2 and 4 (each within the scatter of the next); then compounds 1 and 3 (each within the scatter of the next).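

In this assay methoxy does not hold the level of chloro on this aromatic carbon, ortho to a large group and meta to a fluoro group (a number 18 percentage points lower from compound 3 to compound 4 (beyond the scatter)). Methoxy and methyl read alike at this place (a number 3 percentage points higher from compound 2 to compound 4 (within the scatter)), so chloro now stands apart from two replacements rather than one, on the three compounds that share the fluoro group's place only in part of the comparison: compounds 2, 3 and 4. The 2-fluoro-6-methoxyphenyl group also falls short of 2-(trifluoromethoxy)phenyl (a number 11 percentage points lower from compound 1 to compound 4 (beyond the scatter)), so the two oxygen-linked groups do not read alike, though the group in compound 1 carries no fluoro.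

Nothing measured here explains these differences. As far as these compounds go, whether a nitrile or a bromo group on this carbon would read with chloro, or with methyl and methoxy, stays open.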